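The compounds below may be only part of what the source reports. "The series", "measured", "known", "first", "only" and "open" are said of these compounds alone.

Compound 1 `CCC[S+]([O-])c1sc2nc(-c3cccs3)cc(-c3ccccc3)c2c1N` gives 2.1 nM in an assay for inhibition of 15-hydroxyprostaglandin dehydrogenase [NAD(+)] (Homo sapiens), read by fluorescence, with a stated time of 15 min, in the presence of a further agent that is not named here; a higher number here means a weaker inhibitor, a lower number a stronger inhibitor. Compound 3 `CCCC[S+]([O-])c1sc2nc(-c3ccccc3)nc(-c3ccccc3)c2c1N` gives 4.9 nM in this assay, and compound 2 `CCC[S+]([O-])c1sc2ncccc2c1N` gives 151 nM. Compound 1 thus holds the lowest of the three numbers; its nearest neighbour is compound 3, its furthest compound 2, both beyond the scatter. Compound 4 `CCOC(=O)c1sc2nc(-c3cccs3)cc(-c3ccccc3)c2c1N` is not yet measured in this assay. It differs from compound 1 at one place: a group of 5 heavy atoms (3 carbon, 2 oxygen; no ring) in place of a group of 5 heavy atoms (3 carbon, 1 oxygen, 1 sulfur; no ring), on an aromatic carbon. Among the compounds with values here, no measured pair shows this change, so no step of the same kind can be consulted. The step of a 14-fold higher number from compound 1 to compound 4 (1.15 log units; beyond the scatter) is expected to run toward a higher number, beyond the scatter. For compound 4 the expected value is 30 nM, with a range of 5 nM to 200 nM.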

Compound 4, half-maximal inhibitory concentration: > 7500 nM
Compound 4: a limit, no number (the forecaster's own chance of this, stated with the estimate: 3%); middle value at least 250-fold (2.39 log units) from the limit.
By their numbers in this assay, from the lowest: compound 1; then compound 3; then compound 2. At a limit, above all of these: compound 4.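

Replacing the sulfur-bearing group with ethoxycarbonyl on this aromatic carbon, with the heavy-atom count unchanged, gives an at least 3500-fold higher number from compound 1 to compound 4 (3.55 log units; beyond the scatter). Within the data shown here, all the earlier compounds carry a group with sulfur and oxygen here, so they did not show that activity depends so strongly on what occupies this position. The reading for compound 4 is a limit, not a number: the limit of > 7500 nM in this assay, at which 1 of the 4 values shown sits.

Only one replacement at this position is shown, so the part played by the carbonyl or the ethyl end remains open. A carboxylic acid, an amide or a nitrile here could separate these.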